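The compounds below may be only part of what the source reports. "The series", "measured", "known", "first", "only" and "open" are said of these compounds alone.

Working notes on the series. Three compounds of the shared core carry a different aryl group; all were measured in an assay on CHO cells for inhibition of Glucagon receptor (Homo sapiens), tested at 20 uM; a lower number here means less inhibition, a higher number more inhibition at the concentration tested (going by the name of the read-out). Compound 1 `CCCCCc1c(C(C)C)nc(C(C)C)c(CO)c1-c1cccc(Cl)c1` gives 49%. Compound 2 `CCCCCc1c(C(C)C)nc(C(C)C)c(CO)c1-c1cccc(C)c1` gives 46%. Compound 3 `CCCCCc1c(C(C)C)nc(C(C)C)c(CO)c1-c1cccc(C(F)(F)F)c1` gives 25%. Compound 2 stands second highest of the three numbers: its nearest neighbour is compound 1, and the step of a number 3 percentage points lower from compound 1 to compound 2 (within the scatter) is within the scatter; its furthest is compound 3, and the step of a number 21 percentage points lower from compound 2 to compound 3 (beyond the scatter) is beyond the scatter. The step of a number 24 percentage points lower from compound 1 to compound 3 (beyond the scatter) is of the same kind.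

Compound 4 `CCCCCc1c(C(C)C)nc(C(C)C)c(CO)c1-c1ccc(Cl)cc1Cl` is not yet measured. Its change from compound 2 is 2,4-dichlorophenyl in place of 3-methylphenyl on an aromatic carbon. For the measured compounds named here, the steps that bear on it are those between chloro and methyl, which was within the scatter, and from either to trifluoromethyl, which was a modest drop; no measured step covers a second chloro on the aryl group. On that basis compound 4 is expected to stay close to compound 2 in this assay, with a step of a number 3 percentage points lower from compound 2 to compound 4 (within the scatter) estimated as not beyond the scatter. The estimate for compound 4 is 43%, expected between 18% and 65%.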

Compound 4, a percentage reported as inhibition, at one concentration (the size of the read-out at that concentration, not a potency): 8%
The estimate for compound 4 lay 35 percentage points above the measured number, and the stated range ends above it.
By their numbers in this assay, from the lowest: compound 4; then compound 3; then compounds 2 and 1 (each within the scatter of the next).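

In this assay, for the compounds shown here, the aryl group opposite the ring nitrogen proves more sensitive to change than the earlier compounds showed: the step of a number 38 percentage points lower from compound 2 to compound 4 (beyond the scatter) and the step of a number 41 percentage points lower from compound 1 to compound 4 (beyond the scatter) are both large, whereas the earlier steps at this position were modest or within the scatter. Both steps change the number of chloro groups and their placement on the aryl group together, and these compounds cannot separate the two changes. Nothing available bears on the reason for the drop.

The compounds shown leave open whether 2-chlorophenyl or 4-chlorophenyl alone would track compound 4 or compound 1. Also open, going by these compounds, is how an aryl group carrying a methoxy group, an amine or a carboxylic acid would read in this assay.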